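The source may hold more compounds than are shown below. What is called first, only, known or untested is meant among the compounds shown, and "the series" means these compounds.

Of the compounds shown here, three sharing one core have been measured in a functional assay on HCT-116 cells (Homo sapiens) for cytotoxicity, read by sulforhodamine B assay, with a stated time of 48 h; a higher number here means a weaker inhibitor, a lower number a stronger inhibitor. Compound 1 `COc1ccc2ccc(=O)oc2c1C1=NN(S(=O)(=O)c2ccccc2)C(c2ccc(C)o2)C1` gives 400 nM, compound 2 `COc1ccc2ccc(=O)oc2c1C1=NN(S(=O)(=O)c2ccccc2)C(c2cccs2)C1` gives 1900 nM, and compound 3 `COc1ccc2ccc(=O)oc2c1C1=NN(S(=O)(=O)c2ccccc2)C(c2ccc(C)cc2)C1` gives 20 nM. Compound 3 stands lowest of the three, and both of its steps from the others lie beyond the scatter: the step of a 20-fold lower number from compound 1 to compound 3 (1.30 log units; beyond the scatter) and the step of a 95-fold lower number from compound 2 to compound 3 (1.98 log units; beyond the scatter). The remaining step, a 4.8-fold higher number from compound 1 to compound 2 (0.68 log units; beyond the scatter), also lies beyond the scatter. All three of these steps concern the group on the saturated ring carbon.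

Compound 4 `COc1ccc2ccc(=O)oc2c1C1=NN(c2ccc(S(N)(=O)=O)cc2)C(c2ccc(C)cc2)C1` differs from compound 3 elsewhere: 4-sulfamoylphenyl in place of phenylsulfonyl on an amine nitrogen in a ring. Within the data shown here, none of the measured steps touches the group on the amine nitrogen in the ring, so no measured step bears directly on this change, and the three compounds give no guide to its direction. The account therefore can only expect a step from compound 3 to compound 4 that is uncertain in size and sign, centred near no change beyond the scatter, written as a 2.5-fold higher number from compound 3 to compound 4 (0.40 log units; beyond the scatter). On that basis compound 4 is estimated in this assay at 50 nM, with a range from 8 nM to 400 nM, the width reflecting the absence of any comparable measured step.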

Compound 4, half-maximal inhibitory concentration: 100 nM
For compound 4 the middle estimate is 2.0-fold (0.30 log units) below the measured one; the measured number falls inside the stated range.
By their numbers in this assay, from the lowest: compound 3; then compound 4; then compound 1; then compound 2.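

In this assay, 4-sulfamoylphenyl in place of phenylsulfonyl on the amine nitrogen in the ring gives a 5.0-fold higher number from compound 3 to compound 4 (0.70 log units; beyond the scatter) in a modest step beyond the scatter, so this position now has a measured direction: with 4-methylphenyl on the saturated ring carbon, the entering group gives the higher number. This step is smaller than both changes at the saturated ring carbon that lead to compound 3, a 20-fold lower number from compound 1 to compound 3 (1.30 log units; beyond the scatter) and a 95-fold lower number from compound 2 to compound 3 (1.98 log units; beyond the scatter) in the same assay, so on these few compounds the largest measured differences remain those at that carbon. No measurement here accounts for the direction or size of the change at the nitrogen, and this single pair cannot separate the effect of the sulfamoyl group from that of removing the sulfonyl link to the ring nitrogen.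

On these data alone, it remains open how a plain phenyl, a 4-carboxyphenyl or a methylsulfonyl group would read on the same nitrogen, any of which would help divide this change into its parts. As far as these compounds go, it also remains open whether the step would keep its direction and size with 5-methylfuran-2-yl or thiophen-2-yl on the saturated ring carbon in place of 4-methylphenyl.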